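The source may hold more compounds than are shown below. What is called first, only, known or untested is meant among the compounds shown, and "the series" means these compounds.

Compound 1 `O=S(=O)(C1=C(Cl)NC2SC=CN12)c1cn(C2CCNC2)c2ncccc12`: 1 nM
Compound 2 `CCN1CCCC(n2cc(S(=O)(=O)c3ccc(Cl)s3)c3cccnc32)C1`: 3.2 nM

In an assay on HeLa cells for displacement of a labelled ligand from 5-hydroxytryptamine receptor 6 (Homo sapiens) (on this read-out higher numbers stand for weaker inhibition and lower numbers for stronger inhibition), compound 1 gives 1 nM, the lower of the two numbers shown. Compound 2 gives 3.2 nM, and that gap lies beyond the usual scatter. Compound 3 `O=S(=O)(C1=C(Cl)NC2SC=CN12)c1cn(C2CCCNC2)c2ncccc12` differs from compound 1 in one place: piperidin-3-yl in place of pyrrolidin-3-yl on an aromatic nitrogen. Within the data shown here, no step between measured compounds shows what this change does, so in this assay only a small step is expected, in no set direction, and probably within the scatter. Compound 3 is expected to give about 1.5 nM, somewhere between 0.5 nM and 5 nM. This estimate means a step of a 1.5-fold higher number from compound 1 to compound 3 (0.18 log units; within the scatter).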

Compound 3, inhibition constant: 0.7 nM
For compound 3 the middle estimate is 2.1-fold (0.33 log units) above the measured one; the measured number falls inside the stated range.
By their numbers in this assay, from the lowest: compounds 3 and 1 (each within the scatter of the next); then compound 2.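

In this assay, piperidin-3-yl in place of pyrrolidin-3-yl on an aromatic nitrogen gives a 1.4-fold lower number from compound 1 to compound 3 (0.15 log units; within the scatter) and so the two compounds read alike. Among these compounds, this first single-place step shows that, on the core of compound 1, this position takes either the five-membered or the six-membered ring, which the earlier compounds could not show. No supporting measurement offers a reason for this result. On these data alone, how a cyclohexyl ring or an open aminoethyl chain would read at this position remains open, and so does the effect of a methyl group on the ring nitrogen.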